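Cytotoxicity of a triazole-linked sulfonamide series in gastric cells

The compounds below may be only part of what the source reports. "The series", "measured", "known", "first", "only" and "open" are said of these compounds alone.

Measured so far:
compound 1 `O=c1[nH]cc(S(=O)(=O)Nc2ccc(-c3cn(-c4ccccc4)nn3)cc2)c(=O)[nH]1` – "not toxic" (no number reported)
compound 2 `Cc1cccc(-n2cc(-c3ccc(NS(=O)(=O)c4c[nH]c(=O)[nH]c4=O)cc3)nn2)c1` – 28300 nM
compound 3 `O=c1[nH]cc(S(=O)(=O)Nc2ccc(-c3cn(-c4cccc(F)c4)nn3)cc2)c(=O)[nH]1` – "not toxic" (no number reported)

In an ADME assay on GES1 cells (Homo sapiens) for cytotoxicity, read by MTT assay, with a stated time of 24 h (a higher number here means that more compound is tolerated, a lower number that less compound is tolerated), compound 3 is reported as "not toxic" (no number reported) without a single number. Compound 1 shares this kind of entry, also reported as "not toxic" (no number reported) with no number behind it. Only compound 2 carries a number in this assay, giving 28300 nM. So compound 3 stands among the compounds of the shared core for which no numerical value is given, and it cannot be placed in order against compound 2 on the numbers shown.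

Compound 4 `O=c1[nH]cc(S(=O)(=O)Nc2ccc(-c3cn(-c4ccc(Cl)cc4)nn3)cc2)c(=O)[nH]1` has not been measured. It differs from compound 3 by 4-chlorophenyl in place of 3-fluorophenyl on an aromatic nitrogen. Among the measured compounds shown here, no step between measured compounds in this assay is available that would show how such a change moves the read-out, and the two entries without numbers leave no scale to work from. A step of no more than the usual scatter in this assay is expected, in no particular direction, with a real chance that compound 4 is again reported without a number. For compound 4 in this assay an estimate of 40000 nM is given, with an expected range from 15000 nM to 150000 nM.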

Compound 4, half-maximal cytotoxic concentration: 23300 nM
Beside the measured number, compound 4's estimate is 1.7-fold (0.23 log units) above it; the measured number falls inside the stated range.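

Among the compounds shown here, with compound 4, a second substituted phenyl group on the aromatic nitrogen carries a number in this assay, and this gives the only readable step at this position: a 1.2-fold lower number from compound 2 to compound 4 (0.08 log units; within the scatter) for 4-chlorophenyl in place of 3-methylphenyl. Exchanging these two groups therefore leaves the read-out within the usual scatter, while the steps from compound 1 and compound 3 to compound 4 cannot be read: the entries for those two compounds hold a description and no number. No supporting evidence is available to explain this result.

The compounds shown leave open how the unsubstituted phenyl and 3-fluorophenyl groups would compare numerically with 3-methylphenyl and 4-chlorophenyl, so no order can be set across all four groups at this position. They also leave open whether the read-out would stay within the scatter with an amine or a carboxylic acid on the phenyl group, or with a longer alkyl chain in place of the phenyl group on the aromatic nitrogen.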